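The compounds below may be only part of what the source reports. "The series", "measured", "known", "first", "only" and "open" are said of these compounds alone.

Compound 1 `O=S(=O)(Nc1cccc(CO)c1O)c1ccc(-c2ccc(Br)cc2)cc1`: > 5000 nM
Compound 2 `O=S(=O)(Nc1ccc(CO)c(CO)c1)c1ccc(-c2ccc(F)cc2)cc1`: 1000 nM
Compound 3 `CN(c1cccc(CO)c1)S(=O)(=O)c1ccc(-c2ccc(Cl)cc2Cl)cc1`: 2200 nM

All three were tested in a functional assay on J774 cells (Mus musculus) for cytotoxicity, read by resazurin assay, with a stated time of 72 h; on this read-out lower numbers stand for stronger inhibition and higher numbers for weaker inhibition. For compound 1 the assay reports only a limit, not a number: compound 1 sits at the limit of > 5000 nM in this assay, at which 1 of the 3 values shown sits. So where compound 1 truly stands among the numbers shown is open; it is only known that its value lies at that limit. Compound 2 gives 1000 nM in this assay, and compound 3 gives 2200 nM; these two values lie within the usual scatter of each other.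

The step followed here leads from compound 1 to compound 4 `O=S(=O)(Nc1cccc(CO)c1)c1ccc(-c2ccc(Br)cc2)cc1`, a compound not yet measured. The change is hydrogen in place of hydroxy on an aromatic carbon, ortho to a hydroxymethyl group and ortho to a large group. For the measured compounds named here, no pair of measured compounds differs in just this way, so there is no measured step to lean on. Since compound 1 is known only as a limit, the expected step from compound 1 to compound 4 in this assay, an at least 1.2-fold lower number from compound 1 to compound 4 (0.09 log units; that floor lies within the scatter), is itself uncertain and could well stay within the scatter. Compound 4 is expected to give about 4000 nM, with a likely range from 1500 nM to 12000 nM.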

Compound 4, half-maximal inhibitory concentration: 2500 nM
Compound 4: the middle estimate sits 1.6-fold (0.20 log units) above what was measured; the measured number falls inside the stated range.
By their numbers in this assay, from the lowest: compound 2; then compounds 3 and 4 (each within the scatter of the next). At a limit, above all of these: compound 1.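

In this assay, putting hydrogen in place of hydroxy on an aromatic carbon, ortho to a hydroxymethyl group and ortho to a large group, now has a step that can be read: an at least 2.0-fold lower number from compound 1 to compound 4 (0.30 log units; that floor lies within the scatter). For the compounds shown here, compound 4 gives a real number for the core of compound 1 without this hydroxy, which none of the earlier compounds offered, and so it is the first direct look at what this one change does. The size of the change remains only a floor, because the value for compound 1 is a limit and not a number: the limit of > 5000 nM in this assay, at which 1 of the 4 values shown sits.

The compounds shown leave open how large the step truly is, whether it lies within the scatter or beyond it, and whether it would hold on other cores, as compound 2 and compound 3 each differ from compound 4 in more than one place. Also open, as far as these compounds go, is what an amine, a methoxy group or a fluorine on this same aromatic carbon would do to the number in this assay.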